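Working notes: carboxy analogue of compound 1

The source may report more compounds than this note shows. Statements on the series, on what has been measured and on what is new or still open speak of the compounds shown alone.

Measured compounds:
compound 1 `COc1ccc(-c2cc(-c3ccc(S(=O)(=O)NC4CC4)cc3)cnc2N)cn1`: 2.7
compound 2 `COc1ccc(-c2cc(-c3ccc(S(C)(=O)=O)c(F)c3)cnc2N)cn1`: 2.5
compound 3 `COc1ccc(-c2cc(-c3ccc4nccn4c3)cnc2N)cn1`: 2.4

In a physicochemical assay for lipophilicity, at pH 7.4 (on this read-out higher numbers stand for higher lipophilicity and lower numbers for lower lipophilicity), compound 1 gives 2.7, the highest of the three numbers. Compound 2 gives 2.5 and compound 3 gives 2.4, both within the scatter of compound 1, so no ranking among the three is claimed.

Compound 4 `COc1ccc(-c2cc(-c3ccc(C(=O)O)cc3)cnc2N)cn1` differs from compound 1 by carboxy in place of cyclopropylsulfamoyl on an aromatic carbon. Going by the values given here, no step between measured compounds covers this kind of change, so its size cannot be read across from the series. A large downward step in this assay is expected, well beyond the scatter. Compound 4 is estimated at 0.3, with a range from -0.6 to 1.2. This estimate means an expected step of a number 2.40 log units lower from compound 1 to compound 4 (beyond the scatter).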

Compound 4, distribution coefficient: 0.8
For compound 4 the middle estimate is 0.50 log units below the measured one, within the range that was stated.
By their numbers in this assay, from the lowest: compound 4; then compounds 3, 2 and 1 (each within the scatter of the next).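

In this assay, going by these compounds alone, carboxy in place of cyclopropylsulfamoyl on an aromatic carbon gives a number 1.90 log units lower from compound 1 to compound 4 (beyond the scatter) and this is the only step beyond the scatter. Compound 1, compound 2 and compound 3 lie within the scatter of each other, so they gave no sign that this position could carry a large shift. With the rest of compound 1 unchanged, a single replacement here is enough to produce one.

Going by these compounds, how a primary carboxamide or a methyl ester in the same place would read in this assay stays open. Nothing available accounts for the size of this step.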